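Swapping One Five-Membered Ring for Another on the Amide

The source may report more compounds than this note shows. Statements on the series, on what has been measured and on what is new or still open speak of the compounds shown alone.

Measured so far:
compound 1 `CCCCNc1nc(N)nc2c1CN(Cc1ccco1)CC2` gives 0.08 uM
compound 2 `CCCCNc1nc(N)nc2c1CN(C(=O)c1csnn1)CC2` gives 0.1 uM

Both compounds were tested in an assay on HEK293 cells for agonist activity at Toll-like receptor 8 (Homo sapiens), read by a luciferase reporter, with a stated time of 6 h; on this read-out higher numbers stand for an effect only at larger amounts of compound and lower numbers for an effect already at smaller amounts. Within the data shown here, compound 2 holds the higher of the two numbers, but its only neighbour is compound 1, and the step of a 1.3-fold higher number from compound 1 to compound 2 (0.10 log units; within the scatter) lies within the scatter, so the two are effectively level.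

Compound 3 `CCCCNc1nc(N)nc2c1CN(C(=O)c1cc(C)on1)CC2` is not yet measured. It differs from compound 2 at one place: 5-methyl-1,2-oxazol-3-yl in place of 1,2,3-thiadiazol-4-yl on a carbonyl carbon. Among the measured compounds shown here, the only measured step, a 1.3-fold higher number from compound 1 to compound 2 (0.10 log units; within the scatter), touches the same amine nitrogen in a ring and shows that exchanging the group there left the number essentially unchanged. The present change is smaller still, one five-membered aromatic ring for another on the carbonyl carbon, so no step beyond the scatter is expected in this assay, in either direction.

For compound 3 the estimated step is a 1.2-fold higher number from compound 2 to compound 3 (0.08 log units; within the scatter). Compound 3 is therefore expected to give about 0.12 uM, between 0.04 uM and 0.4 uM.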

Compound 3, minimum effective concentration: 0.4 uM
The estimate for compound 3 lay 3.3-fold (0.52 log units) below the measured number; measured number inside the range.
By their numbers in this assay, from the lowest: compounds 1 and 2 (each within the scatter of the next); then compound 3.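

In this assay, among these compounds, the group on the carbonyl carbon proves able to move the number: the change to 5-methyl-1,2-oxazol-3-yl gives a 4.0-fold higher number from compound 2 to compound 3 (0.60 log units; beyond the scatter) and is the first step here beyond the scatter. Compound 3 also separates from the furan-bearing compound through a 5.0-fold higher number from compound 1 to compound 3 (0.70 log units; beyond the scatter) even though compound 2 stayed level with compound 1, so having a carbonyl on this ring nitrogen does not by itself set the number. Whether the change in ring hetero atoms or the methyl matters more cannot be told, and nothing measured here points to a cause.

Still open, as far as these compounds go, is whether plain 1,2-oxazol-3-yl without the methyl would sit with compound 2 or with compound 3. From the compounds shown here alone, how a phenyl ring or a short alkyl chain on the same carbonyl carbon would behave also remains unknown.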